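Swapping a furan ring for dichlorophenyl on a pyrazoline core

The compounds below may be only part of what the source reports. "The series", "measured", "known", "first", "only" and "open" are said of these compounds alone.

Measured compounds:
- compound 1, `COc1ccc(C2=NN(C(=O)C(C)Br)C(c3c(Cl)cccc3Cl)C2)cc1OC`, 51%
- compound 2, `COc1ccc(C2=NN(C(=O)C(C)O[N+](=O)[O-])C(c3ccco3)C2)cc1OC`, 35%

Of the compounds shown here, two have been tested in a functional assay on the whole organism (strain albino) for inhibition, with Rattus norvegicus as the target, read by paw edema, with stated times of 30 min and 1 h, at a dose of 100 mg/kg by the oral route; on this read-out higher numbers stand for more inhibition at the one dose given (going by the name of the read-out) and lower numbers for less inhibition. Compound 1 gives 51%, while compound 2 gives 35%. Compound 2 therefore holds the lowest of the two numbers, and the gap to compound 1 lies beyond the usual scatter of this measurement.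

The next compound, compound 3 with structure `COc1ccc(C2=NN(C(=O)C(C)O[N+](=O)[O-])C(c3c(Cl)cccc3Cl)C2)cc1OC`, is not yet measured in this assay . It departs from compound 2 in a single place: 2,6-dichlorophenyl in place of furan-2-yl on a saturated ring carbon. Compound 3 thus carries the same ring that compound 1 carries on that saturated ring carbon, though the two are not otherwise directly comparable, and compound 1 and compound 3 differ elsewhere as well.

Because compound 1 gives 51% with this same 2,6-dichlorophenyl group, the step is expected to run upward, about a number 10 percentage points higher from compound 2 to compound 3 (within the scatter), roughly at the edge of the scatter. Compound 3 is estimated at 45%, with a likely range from 30% to 60%.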

Compound 3, a percentage reported as inhibition, in the whole organism at one dose (the size of the read-out at that dose, not a potency): 47%
For compound 3 the middle estimate is 2 percentage points below the measured one; the measured number falls inside the stated range.
By their numbers in this assay, from the lowest: compound 2; then compounds 3 and 1 (each within the scatter of the next).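

In this assay, 2,6-dichlorophenyl in place of furan-2-yl on a saturated ring carbon gives a number 12 percentage points higher from compound 2 to compound 3 (beyond the scatter), the first sign that the read-out responds to the ring at this position when the rest of the molecule stays the same. Nitrooxy in place of bromo on the saturated chain carbon gives a number 4 percentage points lower from compound 1 to compound 3 (within the scatter), so the two groups cannot be told apart in this read-out at this one dose when 2,6-dichlorophenyl is present. No measurement available here explains either step.

Going by these compounds alone, with only two rings compared at the saturated ring carbon, it remains open whether the step depends on the two chlorine atoms or on the six-membered carbon ring itself, a question that an unsubstituted phenyl ring there would help to answer. Also open, going by these compounds, are whether bromo and nitrooxy would still match with furan-2-yl on the ring carbon, and how a hydroxyl group or an amine would compare on the chain carbon.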